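Trading an Ester Side Chain for a Bromophenyl Acid

A few compounds are considered here, and "the series" means these few. Any claim that something is new, unique, unknown or untested is made for them only; others in the source may bear on it.

Of the compounds shown here, two have been tested in a functional assay on K562 cells (Homo sapiens) for cytotoxicity, read by trypan blue exclusion, with a stated time of 96 h; on this read-out lower numbers stand for stronger inhibition and higher numbers for weaker inhibition. Compound 1 `COc1cc(OC)c(/C=C/S(=O)(=O)Cc2ccc(OC)cc2[N+](=O)[O-])c(OC)c1` gives 20000 nM, while compound 2 `COC(=O)[C@H](C)Nc1cc(CS(=O)(=O)/C=C/c2c(OC)cc(OC)cc2OC)ccc1OC` gives 200 nM, the lower of the two numbers and far apart from compound 1. Compound 3 `COc1cc(OC)c(/C=C/S(=O)(=O)Cc2ccc(OC)c(NC(C(=O)O)c3ccc(Br)cc3)c2)c(OC)c1` differs from compound 2 in one place: (4-bromophenyl)(carboxy)methyl in place of 1-(methoxycarbonyl)ethyl on a nitrogen on an aromatic ring. Among the compounds with values here, no measured pair shows a change of this kind, so the step is expected to be modest, if anything toward a higher number, with a 2.0-fold higher number from compound 2 to compound 3 (0.30 log units; within the scatter) as the estimate. Compound 3 is therefore expected to give about 400 nM, within 80 nM to 2000 nM.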

Compound 3, half-maximal inhibitory concentration: 200 nM
Beside the measured number, compound 3's estimate is 2.0-fold (0.30 log units) above it; measured number inside the range.
By their numbers in this assay, from the lowest: compounds 2 and 3 (each within the scatter of the next); then compound 1.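

In this assay putting (4-bromophenyl)(carboxy)methyl in place of 1-(methoxycarbonyl)ethyl on the nitrogen gives no change at the digits printed from compound 2 to compound 3 (within the scatter) even though the side chain grows from 6 to 11 heavy atoms and gains an aromatic ring. This position therefore tolerates this larger group with its carboxy end. Nothing available explains why the two side chains read alike. As far as these compounds go, this single swap changes the ring, the bromine and the ester at once, so their separate contributions stay unknown. From the compounds shown here alone, how a plain amine or a (4-bromophenyl)(methoxycarbonyl)methyl group on this nitrogen would read remains open.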